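Acyl thiourea series: swapping the aryl group for a styryl

A few compounds are considered here, and "the series" means these few. Any claim that something is new, unique, unknown or untested is made for them only; others in the source may bear on it.

Compound 2 `COc1cc(C(=O)NC(=S)Nc2cc3[nH]c(=O)cnc3cc2N(C)C2CCCCC2)cc(OC)c1OC` — 15900 nM in an ADME assay on Huh-7 cells (Homo sapiens) for cytotoxicity; on this read-out higher numbers stand for weaker inhibition and lower numbers for stronger inhibition
Compound 1 `CN(c1cc2ncc(=O)[nH]c2cc1NC(=S)NC(=O)c1cccc(C(F)(F)F)c1)C1CCCCC1` — 31500 nM in this assay

Two compounds share the core and differ only at the group on the carbonyl carbon. In this assay compound 2 stands beside compound 1, the two numbers lying within the scatter of each other: the step of a 2.0-fold lower number from compound 1 to compound 2 (0.30 log units; within the scatter) shows that changing the aryl group there did not move the read-out beyond the noise.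

Compound 3 `CN(c1cc2ncc(=O)[nH]c2cc1NC(=S)NC(=O)/C=C/c1ccccc1)C1CCCCC1` carries the change (2-phenylethenyl in place of 3,4,5-trimethoxyphenyl on a carbonyl carbon). Going by the values given here, the one measured step that bears on this place, a 2.0-fold lower number from compound 1 to compound 2 (0.30 log units; within the scatter), was within the scatter, so another exchange at the same carbonyl carbon is expected to give a step of similar size, with no clear direction. For compound 3 the expected value is 20000 nM, in a range from 7000 nM to 60000 nM. The step this estimate means is a 1.3-fold higher number from compound 2 to compound 3 (0.10 log units; within the scatter), which is expected to stay within the scatter.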

Compound 3, half-maximal inhibitory concentration: 11000 nM
Compound 3: middle estimate off by 1.8-fold (0.26 log units), on the high side; measured number inside the range.
By their numbers in this assay, from the lowest: compounds 3, 2 and 1 (each within the scatter of the next, the first and the last beyond it).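

In this assay, going by these compounds alone, the 2-phenylethenyl group gives the first step at this carbonyl carbon that lies beyond the scatter, though only a modest one (a 2.9-fold lower number from compound 1 to compound 3 (0.46 log units; beyond the scatter)). Set against the 3,4,5-trimethoxyphenyl group, the same group stays within the scatter (a 1.4-fold lower number from compound 2 to compound 3 (0.16 log units; within the scatter)), so exchanging that group's hydrogen-bond acceptors for a double bond outside the aromatic ring does not clearly move the read-out. Nothing measured here explains the difference from compound 1.

As far as these compounds go, it remains open how a 2-phenylethyl group, the same chain without the double bond, would compare at this carbonyl carbon. Also open, from the compounds shown here alone, is whether an aromatic ring is needed there at all, which a cyclohexyl group would test, and how an amine or a carboxylic acid on the phenyl ring would read.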